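A few compounds are considered here, and "the series" means these few. Any claim that something is new, unique, unknown or untested is made for them only; others in the source may bear on it.

Working notes on the series. Going by the values given here, in a functional assay on PANC-1 cells (Homo sapiens) for inhibition, read by MTT assay, with a stated time of 24 h, tested at 10 uM (a lower number here means less inhibition, a higher number more inhibition at the concentration tested (going by the name of the read-out)), compound 2 `CC(C)=CCC/C(C)=C/CC1Cc2c(OCCCNS(=O)(=O)c3ccc(C(F)(F)F)cc3)cc(=O)n(CCCO)c2CC1(C)C` gives 26.4%, and compound 1 `CC(C)=CCC1Cc2c(OCCCNS(=O)(=O)c3ccc(C(F)(F)F)cc3)cc(=O)n(CCCO)c2CC1(C)C` gives 29.6%, the two numbers lying within the usual scatter of each other; the one measured step, a number 3.2 percentage points lower from compound 1 to compound 2 (within the scatter), changes only the side chain of the shared core. Compound 3 `CC(C)=CCC/C(C)=C/CC1Cc2c(OCCCNS(=O)(=O)c3ccc(Br)cc3)cc(=O)n(CCCO)c2CC1(C)C` differs from compound 2 by bromo in place of trifluoromethyl on an aromatic carbon. Among the compounds with values here, no measured step touches the 4-(trifluoromethyl)phenyl group, so nothing in the data points to a shift beyond the scatter. For compound 3 the expected step is a number 0.4 percentage points lower from compound 2 to compound 3 (within the scatter). Compound 3 is therefore estimated at 26%, within a range from 14% to 38%.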

Compound 3, a percentage reported as inhibition, at one concentration (the size of the read-out at that concentration, not a potency): 15.2%
Compound 3: middle estimate off by 10.8 percentage points, on the high side, within the range that was stated.
By their numbers in this assay, from the lowest: compound 3; then compounds 2 and 1 (each within the scatter of the next).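

In this assay, bromo in place of trifluoromethyl on this aromatic carbon gives a number 11.2 percentage points lower from compound 2 to compound 3 (beyond the scatter), so the group at this place can move the read-out beyond the scatter, which the earlier side-chain step did not do. With the side chain and the rest of the shared core unchanged, the step belongs to this one exchange. Nothing measured explains the shift.

As far as these compounds go, what an amine, a carboxylic acid or a methoxy group on this aromatic carbon would give stays open. Also open, from the compounds shown here alone, is whether the same exchange would give a similar step on the shorter side chain of compound 1.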